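A Carboxy Group on the Sulfonyl Ring

The source may report more compounds than this note shows. Statements on the series, on what has been measured and on what is new or still open speak of the compounds shown alone.

Among the compounds with values here, in an ADME assay on Vero cells (Chlorocebus sabaeus) for cytotoxicity, read by MTT assay (on this read-out lower numbers stand for higher toxicity in this test and higher numbers for lower toxicity in this test), compound 2 `Cn1nc(C(F)(F)F)cc1C(=O)Nc1ccc(S(=O)(=O)N2CCNCC2)cc1` gives 126000 nM, the only true number so far. Compound 1 `Cn1nc(C(F)(F)F)cc1C(=O)Nc1ccc(S(=O)(=O)N2CCCCC2)cc1` gives > 300000 nM, which is a limit of the assay and not a number. Compound 3 `Cn1nc(C(F)(F)F)cc1C(=O)Nc1ccc(S(=O)(=O)N2CCCCC2C(=O)O)cc1` carries 2-carboxypiperidin-1-yl in place of piperazin-1-yl on a sulfonyl sulfur. Within the data shown here, one measured step bears on this change: an at least 2.3-fold lower number from compound 1 to compound 2 (0.37 log units; beyond the scatter), on going from piperidin-1-yl to piperazin-1-yl. Compound 3 regains the ring of compound 1 but adds a carboxy group, whose effect no measurement shows, so only a partial reversal of an at least 2.3-fold lower number from compound 1 to compound 2 (0.37 log units; beyond the scatter) is expected. The expected change in this assay is a modest move towards lower toxicity, a 2.2-fold higher number from compound 2 to compound 3 (0.35 log units; beyond the scatter). For compound 3 the estimated value is 280000 nM, with a range from 110000 nM to 600000 nM.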

Compound 3, half-maximal cytotoxic concentration: > 300000 nM
Compound 3 ended at the assay's limit (the forecaster's own chance of this, stated with the estimate: 50%); middle value at least 1.0-fold (0.02 log units) from the limit.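

In this assay, 2-carboxypiperidin-1-yl in place of piperazin-1-yl on the sulfonyl sulfur gives an at least 2.3-fold higher number from compound 2 to compound 3 (0.37 log units; beyond the scatter) and so shows that a ring bearing a carboxy group can sit at this place without the lower number of compound 2. Compound 3 gives > 300000 nM in this test, which is a limit of the assay and not a number. The effect of the carboxy group itself on the ring of compound 1 cannot be read, because both compounds stand at the limit: the limit of > 300000 nM in this assay, at which 2 of the 3 values shown sit.

From the compounds shown here alone, whether the carboxy group changes toxicity at all therefore stays open, as no true number exists on either side of that step. Also open, going by these compounds, is whether a methyl ester, an amine or a longer chain ending in a carboxylic acid on the same ring would stay at this limit.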